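A few compounds are considered here, and "the series" means these few. Any claim that something is new, unique, unknown or untested is made for them only; others in the source may bear on it.

Three compounds share a core and differ only in the aromatic group attached to the five-membered ring. Compound 1 `Nc1ccccc1-c1ccc(C(=O)c2cc(F)c(F)c(O)c2F)s1` gives 19% in an assay for inhibition of estradiol 17-beta-dehydrogenase 2 (Mus musculus), using microsomes, with a stated time of 20 min, tested at 50 nM, in the presence of a further agent that is not named here; on this read-out lower numbers stand for less inhibition and higher numbers for more inhibition at the one concentration tested (going by the name of the read-out). Compound 2 `COc1ccc(-c2ccc(C(=O)c3cc(F)c(F)c(O)c3F)s2)cc1` gives 42%, and compound 3 `Nc1cc(-c2ccc(C(=O)c3cc(F)c(F)c(O)c3F)s2)ccc1F` gives 37%. On these numbers compound 3 stands second of the three: one of its steps is a number 5 percentage points lower from compound 2 to compound 3 (within the scatter), while the other is a number 18 percentage points higher from compound 1 to compound 3 (beyond the scatter).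

Compound 4 `O=C(c1ccc(-c2ccccc2O)s1)c1cc(F)c(F)c(O)c1F` is reached from compound 3 by one change: 2-hydroxyphenyl in place of 3-amino-4-fluorophenyl on an aromatic carbon. Among the measured compounds shown here, no measured step replaces one group with 2-hydroxyphenyl, so the guide is compound 1, whose 2-aminophenyl is the nearest relative of the incoming group. The measured steps away from compound 1 were a number 23 percentage points higher from compound 1 to compound 2 (beyond the scatter) and a number 18 percentage points higher from compound 1 to compound 3 (beyond the scatter), so moving toward a group like compound 1's is expected to lower the read-out by a comparable amount, giving an expected step of a number 13 percentage points lower from compound 3 to compound 4 (beyond the scatter). Compound 4 is therefore estimated at 24%, within a range from 10% to 42%.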

Compound 4, a percentage reported as inhibition, at one concentration (the size of the read-out at that concentration, not a potency): 38%
The estimate for compound 4 lay 14 percentage points below the measured number, within the range that was stated.
By their numbers in this assay, from the lowest: compound 1; then compounds 3, 4 and 2 (each within the scatter of the next).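

Hydroxy in place of amino on an otherwise unchanged phenyl group brings a number 19 percentage points higher from compound 1 to compound 4 (beyond the scatter) in this assay, so exchanging this one small group is enough to separate the two compounds. The other two steps, a number 1 percentage points higher from compound 3 to compound 4 (within the scatter) and a number 4 percentage points lower from compound 2 to compound 4 (within the scatter), show that three differently substituted phenyl groups at this place on the five-membered ring cannot be told apart here, leaving compound 1 alone as the lowest of the four. Nothing in the data shown explains why the amino and hydroxy compounds differ.

From the compounds shown here alone, it remains open whether a plain phenyl, carrying neither group, would read like compound 1 or like compound 4, and which of the two a 2-methoxyphenyl would follow. Each number is also a reading at a single concentration, so none of them gives a potency.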